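This account rests on a few compounds, and the source may have more. Where it says the series, first, only, none or still open, it means among the compounds named here.

Measured in an ADME assay on MT4 cells (Homo sapiens) for cytotoxicity, read by MTT assay, with a stated time of 96 h; a higher number here means that more compound is tolerated, a lower number that less compound is tolerated:
Compound 1 `FC(F)(F)c1ccc(-c2nn(-c3ccccc3)cc2CNc2ccc(Cl)cc2)cc1`: > 100000 nM
Compound 2 `Brc1ccc(NCc2cn(-c3ccccc3)nc2-c2ccccc2)cc1`: > 100000 nM
Compound 3 `Cc1ccc(NCc2cn(-c3ccccc3)nc2-c2ccc(Cl)cc2)cc1`: > 100000 nM

All three compounds stand at the limit of > 100000 nM in this assay, at which 3 of the 3 values shown sit. Compound 3 gives > 100000 nM, which is a limit of the assay and not a number.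

Compound 4 `Cc1ccc(NCc2cn(-c3ccccc3)nc2-c2ccc(C(F)(F)F)cc2)cc1` differs from compound 3 by one change, trifluoromethyl in place of chloro on an aromatic carbon. Compound 1 also carries the 4-(trifluoromethyl)phenyl group, and its > 100000 nM is likewise a limit.

On that basis, no step beyond the scatter is expected in this assay, in either direction. The expected change is a number no higher from compound 3 to compound 4 (the limit leaves the size open). For compound 4 the estimate is 100000 nM, with an expected range of 40000 nM to 100000 nM.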

Compound 4, half-maximal cytotoxic concentration: > 100000 nM
Compound 4 ended at the assay's limit; the forecaster's own chance of this, stated with the estimate: 85%; the middle value lies on the limit itself.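

In this assay, going by these compounds alone, compound 4 gives > 100000 nM as a limit of the assay and not a number, so no step from compound 3 or compound 1 to compound 4 can be read. The compounds shown leave open at what concentration any of them becomes cytotoxic.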